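This account rests on a few compounds, and the source may have more. Where it says the series, first, only, none or still open, it means among the compounds named here.

Working notes on the series. Among the measured compounds shown here, compound 2 `Cn1cc2c(-c3cc(F)c(Cn4cnc5cnccc5c4=O)c(F)c3)cccc2n1` gives 0.01 in an ADME assay on a cell-free system (plasma, Rattus norvegicus) for protein binding (a lower number here means a smaller unbound share, a higher number a larger unbound share of the compound), the lowest of the two numbers so far; compound 1 `Cn1cnc2ccc(-c3cc(F)c(Cn4cnc5cnccc5c4=O)c(F)c3)cc21` gives 0.04, and the step of a 4.0-fold lower number from compound 1 to compound 2 (0.60 log units; beyond the scatter) lies beyond the scatter. Compound 3 `O=c1c2ccncc2ncn1Cc1c(F)cc(-c2ccc3cnccc3c2)cc1F` differs from compound 2 by isoquinolin-6-yl in place of 2-methyl-2H-indazol-4-yl on an aromatic carbon. For the measured compounds named here, no measured step covers this particular swap; the only step known, from compound 1 to compound 2, involves a different ring system at the same position and serves merely as a guide to the spread. For compound 3 a step of a 2.0-fold higher number from compound 2 to compound 3 (0.30 log units; within the scatter) is therefore expected, tentatively. Compound 3 is estimated at 0.02, with a range from 0.006 to 0.06.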

Compound 3, unbound fraction: 0.03
The estimate for compound 3 lay 1.5-fold (0.18 log units) below the measured number; the measured number falls inside the stated range.
By their numbers in this assay, from the lowest: compound 2; then compounds 3 and 1 (each within the scatter of the next).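

With isoquinolin-6-yl at this position, [ this assay ] shows a 3.0-fold higher number from compound 2 to compound 3 (0.48 log units; beyond the scatter), whereas a 1.3-fold lower number from compound 1 to compound 3 (0.12 log units; within the scatter) stays within the scatter. Among these three compounds, 2-methyl-2H-indazol-4-yl is therefore the only group that stands apart, with steps beyond the scatter to both other groups. Nothing available explains this difference between the groups. Still open, going by these compounds, is how a group of a different kind at this position, such as a carboxylic acid or an amine, would read in [ this assay ]. Also open, on these data alone, is whether the same order would hold without the two fluoro groups.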